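From a Pyridyl Amide to a Fluorophenyl Amide

This account rests on a few compounds, and the source may have more. Where it says the series, first, only, none or still open, it means among the compounds named here.

Of the compounds shown here, three have been tested in a functional assay on KYSE-70 cells for antiproliferative activity against KYSE-70 cell line (Homo sapiens), read by MTT assay, with a stated time of 72 h; a higher number here means a weaker inhibitor, a lower number a stronger inhibitor. Compound 1 `O=C(Nc1ccc(F)cc1)c1ccnc2cc(Br)ccc12` reaches only the limit of the assay, > 20000 nM, which is not a number. Compound 2 `O=C(c1cc(=O)[nH]c2cc(Br)ccc12)N1CCCCC1`, which carries a piperidin-1-yl group on its carbonyl carbon, also stops at the limit, > 20000 nM. Compound 3 `O=C(Nc1ccccn1)c1cc(=O)[nH]c2cc(Br)ccc12` is the only one to give a measured number, 11000 nM. The other two values shown are not numbers, as summed up by the limit of > 20000 nM in this assay, at which 2 of the 3 values shown sit. Within the data shown here, the single measured step, an at least 1.8-fold lower number from compound 2 to compound 3 (0.25 log units; that floor lies within the scatter), is the one that bears on what follows, and its floor lies within the scatter, so it shows little more than that compound 3 becomes readable where compound 2 was not.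

Compound 4 `O=C(Nc1cccc(F)c1)c1cc(=O)[nH]c2cc(Br)ccc12` differs from compound 3 in one place: 3-fluorophenyl in place of pyridin-2-yl on an amide-type nitrogen. Among the measured compounds shown here, no measured step exchanges one aromatic group for another on the amide-type nitrogen of this core, so nothing in the data points to a large shift in either direction. The step is expected to stay within the scatter, a 1.4-fold higher number from compound 3 to compound 4 (0.13 log units; within the scatter), with a real chance that the assay returns only a limit. Compound 4 is therefore estimated at 15000 nM, with a range from 5000 nM to 40000 nM.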

Compound 4, half-maximal inhibitory concentration: 8900 nM
Compound 4: middle estimate off by 1.7-fold (0.23 log units), on the high side; the range from low to high includes it.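

In this assay, the exchange on the amide-type nitrogen comes out as a 1.2-fold lower number from compound 3 to compound 4 (0.09 log units; within the scatter), so this pair of compounds cannot be told apart. Among these compounds, the result still adds something that the earlier compounds did not show: pyridin-2-yl carries a ring nitrogen counted as a hydrogen-bond acceptor, while 3-fluorophenyl has a ring of carbon only and no such acceptor, yet compound 4 also gives a readable number on the shared core. For this pair, then, a readable value does not depend on the ring nitrogen of compound 3, although values that are only assay limits, not numbers, still make up a large share of the small set: the limit of > 20000 nM in this assay, at which 2 of the 4 values shown sit.

Going by these compounds, it remains open whether any group on this amide-type nitrogen can move the number beyond the scatter, for example a benzyl group, or a phenyl ring carrying an amine or a carboxylic acid. It is also open whether chlorine in place of the bromine on the shared core would change the reading, since every compound shown carries bromine.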